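A few compounds are considered here, and "the series" means these few. Any claim that something is new, unique, unknown or untested is made for them only; others in the source may bear on it.

Compound 2 `Clc1ccccc1-c1nnc(-c2ccncc2)o1` is the reference for this step. Within the data shown here, in a functional assay on the whole organism for inhibition, with Rattus norvegicus as the target, read by paw edema, with a stated time of 4 h, at a dose of 70 mg/kg by the oral route (a lower number here means less inhibition, a higher number more inhibition at the dose given (going by the name of the read-out)), compound 2 gives 37.7%, the lowest of the three numbers measured so far. Compound 3 `Clc1ccc(-c2nnc(-c3ccncc3)o2)c(Cl)c1`, which carries chloro in place of hydrogen on an aromatic carbon, gives 84% in this assay; compound 1 `Clc1ccc(-c2nn3c(-c4ccncc4)nnc3s2)c(Cl)c1`, built on a different core, gives 69.3%. Among the measured compounds shown here, the step of a number 46.3 percentage points higher from compound 2 to compound 3 (beyond the scatter) is the only measured one-place step, and it adds a chloro rather than exchanging one. Compound 4 `Cc1ccccc1-c1nnc(-c2ccncc2)o1` differs from compound 2 by methyl in place of chloro on an aromatic carbon. For the measured compounds named here, no measured step exchanges chloro for methyl, so the added-chloro step tells only that a second chloro raised inhibition, not what replacing the first one with methyl does. The expectation is a step of a number 5.7 percentage points lower from compound 2 to compound 4 (within the scatter), within the scatter or only just beyond it, with a downward lean because a number 46.3 percentage points higher from compound 2 to compound 3 (beyond the scatter) ran upward when chloro content rose. Compound 4 is estimated at 32% in this assay, within 14% to 52%.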

Compound 4, a percentage reported as inhibition, in the whole organism at one dose (the size of the read-out at that dose, not a potency): 43.4%
Compound 4: the middle estimate sits 11.4 percentage points below what was measured, and the stated range covers the measured number.
By their numbers in this assay, from the lowest: compounds 2 and 4 (each within the scatter of the next); then compound 1; then compound 3.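

In this assay, methyl in place of chloro on an aromatic carbon, ortho to a large group, gives a step of a number 5.7 percentage points higher from compound 2 to compound 4 (within the scatter), so at this single dose the two groups cannot be told apart at this position. Among these compounds, this is the first exchange read at this position, and it contrasts with the added chloro elsewhere on the ring, which gave a number 46.3 percentage points higher from compound 2 to compound 3 (beyond the scatter): the chloro at this position can therefore be replaced by methyl with no change beyond the scatter. No measurement here bears on why the two groups read alike.

From the compounds shown here alone, whether the same exchange holds alongside the second chloro, or on the core of compound 1, remains open. Also open, going by these compounds, is how a methoxy group, an amine or a carboxylic acid would read at this position.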